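Chloro for Trifluoromethyl: an Expected Standstill

This account rests on a few compounds, and the source may have more. Where it says the series, first, only, none or still open, it means among the compounds named here.

For the measured compounds named here, compound 1 `O=C(Nc1cccc(-n2cc(-c3ccncc3)c(-c3cc(O)cc(Cl)c3)n2)c1)Nc1ccc(Cl)c(Cl)c1` and compound 2 `COc1cc(Cl)cc(-c2nn(-c3cccc(NC(=O)Nc4ccc(Cl)c(C(F)(F)F)c4)c3)cc2-c2ccncc2)c1` share one core and differ from each other at two places, so no single-change step between measured compounds exists here. In a functional assay on SR cells (Homo sapiens) for inhibition, read by sulforhodamine B assay, with a stated time of 48 h, tested at 100 uM (on this read-out lower numbers stand for a stronger effect and higher numbers for a weaker effect at the one concentration tested), compound 1 gives -30%. In this assay compound 2 gives -30%, which puts compound 2 level with compound 1 at the digits shown, the two values lying within the scatter of each other.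

Compound 3 `COc1cc(Cl)cc(-c2nn(-c3cccc(NC(=O)Nc4ccc(Cl)c(Cl)c4)c3)cc2-c2ccncc2)c1` has not yet been measured. It differs from compound 2 in one place: chloro in place of trifluoromethyl on an aromatic carbon. With this change, compound 3 carries the same 3,4-dichlorophenyl that compound 1 carries, while keeping the rest of compound 2 unchanged.

Nothing in the two measured values points to a shift: the step is expected to be no change at the digits printed from compound 2 to compound 3 (within the scatter), that is, no change beyond the scatter, because compound 1 gives -30% and compound 2 gives -30% with both arrangements of that phenyl. Compound 3 is therefore expected to give about -30%, within a range from -45% to -15%.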

Compound 3, a percentage reported as activity, at one concentration (the size of the read-out at that concentration, not a potency): -26%
Compound 3: middle estimate off by 4 percentage points, on the low side; measured number inside the range.
By their numbers in this assay, from the lowest: compounds 1, 2 and 3 (each within the scatter of the next).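

Read in this assay, chloro in place of trifluoromethyl on this aromatic carbon, ortho to a chloro group and meta to a large group, gives a number 4 percentage points higher from compound 2 to compound 3 (within the scatter). For the compounds shown here, this is the first reading of that change on its own, and it shows that the two groups cannot be told apart here when the oxygen on the other aromatic ring carries a methyl. Compound 3 also isolates the second difference, since methyl in place of hydrogen on that oxygen gives a number 4 percentage points higher from compound 1 to compound 3 (within the scatter), so each of the two changes that separated compound 1 from compound 2 now has its own step, and neither lies beyond the scatter. Nothing measured here offers an explanation for either step.

The compounds shown leave open whether this aromatic carbon would tolerate a quite different group, such as an amine or a nitrile, with the read-out staying within the scatter, and whether a longer chain on the oxygen, such as ethyl, would do the same. They also cover only one cell line at a single concentration, so they cannot say whether either change would matter in another setting.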